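Replacing the Fluoro Group of Compound 2

The source may report more compounds than this note shows. Statements on the series, on what has been measured and on what is new or still open speak of the compounds shown alone.

Three compounds with a shared core are in view. For compound 1 `Cc1ccc(N)cc1S(=O)(=O)N(C)/N=C/c1cnn2ccc(C#N)cc12`, a functional assay on NZB5 cells (Homo sapiens) for inhibition, read by thymidine incorporation, with a stated time of 5 days (on this read-out lower numbers stand for stronger inhibition and higher numbers for weaker inhibition), gives "not determined" (no result reported) as its entry, so it offers no number to compare. Among the compounds with values here, compound 2 `CN(/N=C/c1cnn2ccc(C#N)cc12)S(=O)(=O)c1cc([N+](=O)[O-])ccc1F` gives 480 nM in this assay and holds the only number so far, which means it cannot yet be ranked against anything.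

Compound 3 `CN(C)c1ccc([N+](=O)[O-])cc1S(=O)(=O)N(C)/N=C/c1cnn2ccc(C#N)cc12` has not been measured. It carries dimethylamino in place of fluoro on an aromatic carbon and this carbon is para to a nitro group. Within the data shown here, no measured pair shows what such a replacement does, so the data give no step to borrow. Among the measured compounds shown here, the sole anchor is compound 2 at 480 nM and any expectation must start from there. A moderate weakening in this assay seems more likely than a gain, although a change no larger than the usual scatter is also possible. The expected move is a 1.9-fold higher number from compound 2 to compound 3 (0.27 log units; within the scatter) as a rough estimate. For compound 3 the estimated value is 900 nM with an expected range from 200 nM to 4000 nM in this measurement.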

Compound 3, half-maximal inhibitory concentration: 40 nM
Estimate against measurement, compound 3: 23-fold (1.35 log units) above, and the stated range ends above it.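

In this assay, putting dimethylamino in place of fluoro on this aromatic carbon, which is para to a nitro group and ortho to a large group, gives a 12-fold lower number from compound 2 to compound 3 (1.08 log units; beyond the scatter). This shows that the position is far from silent: it takes a group of three heavy atoms in place of a single fluorine, bringing in one hydrogen-bond acceptor where none stood, and the number falls rather than rises. No measurement shown here explains the size of this step, so it can be recorded but not traced to any one feature of the new group.

It remains open whether the gain depends on the nitrogen alone or also on its two methyl groups, and whether larger groups would hold it, since a plain amine, methylamino, diethylamino and morpholine are not among the compounds shown at this carbon. Compound 1 adds nothing to this question, as its entry is "not determined" (no result reported) and it differs from compound 2 in more than one place.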